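Swapping a fluoro for a tert-butyl on the aryl ketone

A few compounds are considered here, and "the series" means these few. Any claim that something is new, unique, unknown or untested is made for them only; others in the source may bear on it.

Compound 3 `O=C(O)/C=C/C(=O)c1ccc(F)cc1` gives 16900 nM in a functional assay on K562 cells (Homo sapiens) for inhibition, read by MTT assay, with a stated time of 72 h (a lower number here means a stronger inhibitor, a higher number a weaker inhibitor), the lowest of three numbers. Compound 1 `O=C(O)/C=C/C(=O)c1ccccc1` gives 30200 nM, and the step of a 1.8-fold lower number from compound 1 to compound 3 (0.25 log units; within the scatter) is small. Compound 2 `O=C(O)/C=C/C(=O)c1ccc(Cl)cc1Cl`, carrying two chloro groups, gives 58500 nM, a higher number than compound 3. Compound 4 `CC(C)(C)c1ccc(C(=O)/C=C/C(=O)O)cc1` differs from compound 3 by tert-butyl in place of fluoro on an aromatic carbon. Among the compounds with values here, the only measured step that bears on this place, a 1.8-fold lower number from compound 1 to compound 3 (0.25 log units; within the scatter), stayed within the scatter, and no measured compound carries an alkyl group on the ring. A step within the scatter is therefore expected for a 1.1-fold higher number from compound 3 to compound 4 (0.03 log units; within the scatter). Compound 4 is estimated at 18000 nM, within 6000 nM to 54000 nM.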

Compound 4, half-maximal inhibitory concentration: 4330 nM
The estimate for compound 4 lay 4.2-fold (0.62 log units) above the measured number; the measured number lies below the stated range.
By their numbers in this assay, from the lowest: compound 4; then compounds 3, 1 and 2 (each within the scatter of the next, the first and the last beyond it).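

In this assay, within the data shown here, the tert-butyl group gives a 3.9-fold lower number from compound 3 to compound 4 (0.59 log units; beyond the scatter) and a 7.0-fold lower number from compound 1 to compound 4 (0.84 log units; beyond the scatter) at this place, the first steps here beyond the scatter. So this ring carbon is not indifferent to what it carries: tert-butyl stands apart from both fluoro and hydrogen, which lie within the scatter of each other. Nothing measured here explains the drop.

The compounds shown hold no methyl or isopropyl group at this place, so whether the number falls steadily as carbons are added stays open. On these data alone, what a methoxy group or an amine would do there also stays open.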